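Cyclopropylsulfonyl in place of cyclopropylcarbonyl on the shared core

This account rests on a few compounds, and the source may have more. Where it says the series, first, only, none or still open, it means among the compounds named here.

In an ADME assay on the whole organism (plasma) for pharmacokinetics, with Rattus norvegicus as the target (on this read-out lower numbers stand for slow clearance and higher numbers for fast clearance), compound 1 (`N[C@H]1C[C@@H](N2Cc3cnn(S(=O)(=O)C4CCCC4)c3C2)CO[C@@H]1c1cc(F)ccc1F`) gives 96 mL/min/kg and compound 2 (`N[C@H]1C[C@@H](N2Cc3cn(S(=O)(=O)C4CCCC4)nc3C2)CO[C@@H]1c1cc(F)ccc1F`) gives 41 mL/min/kg on the same read-out. Compound 3 (`N[C@H]1C[C@@H](N2Cc3[nH]nc(NC(=O)C4CC4)c3C2)CO[C@@H]1c1cc(F)ccc1F`) gives 64 mL/min/kg and stands within the usual scatter of both of these compounds.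

Compound 4 (`N[C@H]1C[C@@H](N2Cc3[nH]nc(NS(=O)(=O)C4CC4)c3C2)CO[C@@H]1c1cc(F)ccc1F`) carries cyclopropylsulfonyl in place of cyclopropylcarbonyl on a nitrogen on an aromatic ring. Among the measured compounds shown here, no measured pair differs in one place, so the data hold no direct precedent for this change. The expectation therefore rests on compound 3 at 64 mL/min/kg as the starting point, and the range is kept wide. No step beyond the scatter is expected in this assay, and no firm direction can be assigned. The estimated step of a 1.2-fold lower number from compound 3 to compound 4 (0.07 log units; within the scatter) stays within the scatter. For compound 4 the estimated clearance is 55 mL/min/kg with 25 mL/min/kg to 105 mL/min/kg as the expected range.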

Compound 4, clearance: 24 mL/min/kg
Compound 4: middle estimate off by 2.3-fold (0.36 log units), on the high side; the whole stated range lies above it.
By their numbers in this assay, from the lowest: compounds 4, 2, 3 and 1 (each within the scatter of the next, the first and the last beyond it).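

In this assay the series now has its first comparison that differs in one place (a 2.7-fold lower number from compound 3 to compound 4 (0.43 log units; beyond the scatter)), and this step lies beyond the usual scatter. The position is therefore not silent on this read-out: with the rest of the shared core unchanged, going from (cyclopropylcarbonyl)amino to (cyclopropylsulfonyl)amino goes with a modest drop in the number. No measurement at hand gives a reason for this step.

On these data alone, it remains open whether the step is particular to the cyclopropyl pair or also holds for other groups on this nitrogen, such as methylsulfonyl, a urea or a longer acyl chain. A single pair also leaves open whether the same exchange would give a step of similar size on a different core.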